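The compounds below may be only part of what the source reports. "The series", "measured", "known", "first", "only" and "open" are said of these compounds alone.

Working notes on the series. In a functional assay on MCF7 cells (Homo sapiens) for cytotoxicity, read by CellTiter-Glo, with a stated time of 5 days (on this read-out lower numbers stand for stronger inhibition and higher numbers for weaker inhibition), compound 2 `CS(=O)(=O)c1ccc(/C(=C(\c2ccc(/C=C/C(=O)O)cc2)c2ccc3[nH]nc(F)c3c2)C2CCC2)c(Cl)c1` gives 2.3 nM, the lowest of the two numbers recorded so far. Compound 1 `O=C(O)/C=C/c1ccc(/C(=C(\c2ccccc2)C2CCCC2)c2ccc3[nH]ncc3c2)cc1` gives 10 nM in this assay; the gap between compound 2 and compound 1 is beyond the scatter, so compound 2 is the stronger of the two measured compounds. Among the measured compounds shown here, no pair of measured compounds differs in one place only, so there is no single-point step to lean on, and compound 1 and compound 2 differ in several places at once.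

Compound 3 `O=C(O)/C=C/c1ccc(/C(=C(\c2ncc(F)cc2Cl)C2CCC2)c2ccc3[nH]nc(F)c3c2)cc1` is not yet measured. Relative to compound 2 it carries 3-chloro-5-fluoropyridin-2-yl in place of 2-chloro-4-(methylsulfonyl)phenyl on a double-bonded chain carbon bound to a double-bonded chain carbon and a saturated ring carbon. For the measured compounds named here, nothing measured so far isolates this exchange, so the expectation rests on compound 2 alone, with 2.3 nM as the anchor. The step from compound 2 to compound 3 is expected to be a 1.5-fold higher number from compound 2 to compound 3 (0.18 log units; within the scatter), that is a small move towards a higher number, not clearly beyond the scatter. For compound 3 the estimated value in this assay is 3.5 nM, with a range from 0.9 nM to 14 nM.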

Compound 3, half-maximal inhibitory concentration: 1.7 nM
The estimate for compound 3 lay 2.1-fold (0.31 log units) above the measured number; low and high end bracket the measured number.
By their numbers in this assay, from the lowest: compounds 3 and 2 (each within the scatter of the next); then compound 1.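

In this assay the series gains its first step in one place: 3-chloro-5-fluoropyridin-2-yl in place of 2-chloro-4-(methylsulfonyl)phenyl, on a double-bonded chain carbon bound to a double-bonded chain carbon and a saturated ring carbon, gives a 1.4-fold lower number from compound 2 to compound 3 (0.13 log units; within the scatter) and so leaves the number within the scatter. This position therefore accepts either a six-membered aromatic ring of carbon only or one with 1 hetero atom, and the methylsulfonyl group is not required for a number in this range, since compound 3 gives 1.7 nM without it. No measurement at hand explains why the two groups are interchangeable here.

The exchange alters the ring atom, the fluoro group and the methylsulfonyl group together, so the compounds shown cannot say what each of these contributes alone, and compound 1 still differs from both in several places. Also open, from the compounds shown here alone, is whether this position would accept a non-aromatic group such as a morpholine or a primary amine in place of the halogenated aromatic rings.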